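A few compounds are considered here, and "the series" means these few. Any claim that something is new, unique, unknown or untested is made for them only; others in the source may bear on it.

Compound 2 `Nc1nn2c(O)cc(-c3ccccc3)nc2c1[N+](=O)[O-]` carries a plain phenyl on the shared core. In an ADME assay (Homo sapiens) for cytotoxicity (on this read-out lower numbers stand for higher toxicity in this test and higher numbers for lower toxicity in this test), compound 2 gives > 100 ug/mL, which is a limit of the assay and not a number. Among the measured compounds shown here, compound 1 `Nc1nn2c(O)cc(-c3cc([N+](=O)[O-])c(Cl)cc3Cl)nc2c1[N+](=O)[O-]` is the only other compound measured. In this assay compound 1 gives > 100 ug/mL, again a limit of the assay rather than a number. For the measured compounds named here, both values therefore sit at the limit of > 100 ug/mL in this assay, at which 2 of the 2 values shown sit, and compound 2 stands exactly where the one other compound stands, so no order between the two can be read from these values. Compound 3 `Nc1nn2c(O)cc(-c3ccccc3F)nc2c1[N+](=O)[O-]` differs from compound 2 by fluoro in place of hydrogen on an aromatic carbon. Going by the values given here, with no step between measured compounds available and both known values at the limit, the change is expected to produce no step beyond the scatter in this assay. Compound 3 is expected to give 100 ug/mL in this assay, in the range 50 ug/mL to 200 ug/mL. The expected step of a number no higher from compound 2 to compound 3 (the limit leaves the size open) lies within the scatter.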

Compound 3, half-maximal cytotoxic concentration: 66.5 ug/mL
Compound 3: middle estimate off by 1.5-fold (0.18 log units), on the high side; measured number inside the range.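

With fluoro in place of hydrogen on this aromatic carbon, the series gains its first value that is a number and not a limit: in this assay, compound 3 gives 66.5 ug/mL. This gives an at least 1.5-fold lower number from compound 2 to compound 3 (0.17 log units; that floor lies within the scatter), so the phenyl to 2-fluorophenyl change can now be given a floor, though that floor alone does not show a step beyond the scatter. Compound 1 and compound 2 remain at a limit of the assay, which is not a number: the limit of > 100 ug/mL in this assay, at which 2 of the 3 values shown sit.

Going by these compounds, the true size of the step stays open, since one end of it is a limit. Also open, on these data alone, is how a chloro, a methoxy or an amine at this same position would compare with the fluoro of compound 3.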